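This account rests on a few compounds, and the source may have more. Where it says the series, first, only, none or still open, it means among the compounds named here.

Measured so far in an assay for binding affinity to Alpha-1B adrenergic receptor (Homo sapiens); on this read-out higher numbers stand for weaker inhibition and lower numbers for stronger inhibition:
compound 1, `O=c1c2ccccc2c(Cc2ccc(Cl)cc2)nn1CCNCCCCc1ccc(OCCCN2CCCCCC2)cc1`: 316 nM
compound 2, `CN1CCC[C@@H]1Cn1nc(Cc2cccc(Cl)c2)c2ccccc2c1=O`: 631 nM
compound 3, `CN1CCCC1CCn1nc(Cc2ccc(Cl)cc2)c2ccccc2c1=O`: 316 nM

Compound 3 stands level with compound 1 at the digits shown, and the two together hold the lowest numbers of the three. Compound 2 differs from compound 3 only within the usual scatter, so the three compounds cannot be told apart on these numbers.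

Compound 4, `CN1CCC(n2nc(Cc3ccc(Cl)cc3)c3ccccc3c2=O)CC1`, differs from compound 3 by 1-methylpiperidin-4-yl in place of 2-(1-methylpyrrolidin-2-yl)ethyl on an aromatic nitrogen. Within the data shown here, no pair of measured compounds shows such a change, so the expectation rests on the narrow spread of the three numbers. The step of a 1.3-fold higher number from compound 3 to compound 4 (0.10 log units; within the scatter) is expected to stay within the scatter, with no clear direction. Compound 4 is therefore estimated at 400 nM, in a range from 130 nM to 1300 nM.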

Compound 4, inhibition constant: 6.31 nM
The estimate for compound 4 lay 63-fold (1.80 log units) above the measured number, outside the stated range (below it).
By their numbers in this assay, from the lowest: compound 4; then compounds 1, 3 and 2 (each within the scatter of the next).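

In this assay, among these compounds, the group on the aromatic nitrogen matters far more than the earlier compounds suggested: 1-methylpiperidin-4-yl in place of 2-(1-methylpyrrolidin-2-yl)ethyl gives a 50-fold lower number from compound 3 to compound 4 (1.70 log units; beyond the scatter), a large step at this position. The change swaps a five-membered ring for a six-membered one and removes the ethyl link in a single move. Nothing available explains the step.

Which part of the change counts remains open. Also open, going by these compounds, is what 2-(1-methylpiperidin-4-yl)ethyl, which restores the ethyl link, or piperidin-4-yl without the methyl would give here.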